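The source may hold more compounds than are shown below. What is called first, only, known or untested is meant among the compounds shown, and "the series" means these compounds.

Measured so far in a functional assay on MCF7 cells (Homo sapiens) for cytotoxicity, read by MTT assay, with a stated time of 72 h; on this read-out higher numbers stand for weaker inhibition and lower numbers for stronger inhibition:
- compound 1 `COc1ccc(C(=O)NC[C@H]2c3[nH]c4ccccc4c3C[C@H]3[C@H]4c5[nH]c6ccccc6c5C[C@@H]([C@H](C#N)N23)N4C)cc1` gives 600 nM
- compound 2 `CN1[C@@H]2c3[nH]c4ccccc4c3C[C@H]1[C@H](C#N)N1[C@@H](CNC(=O)c3ccc(F)cc3)c3[nH]c4ccccc4c3C[C@@H]21` gives 980 nM
- compound 3 `CN1[C@@H]2c3[nH]c4ccccc4c3C[C@H]1[C@H](C#N)N1[C@@H](CNC(=O)c3cc4ccccc4o3)c3[nH]c4ccccc4c3C[C@@H]21` gives 320 nM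

All three share one core and differ only in the group attached to the carbonyl carbon of the amide. Going by the values given here, compound 3 has the lowest number of the three, but its gap to compound 1 is within the scatter, so only the step of a 3.1-fold lower number from compound 2 to compound 3 (0.49 log units; beyond the scatter) stands out as a real step.

Compound 4 `CN1[C@@H]2c3[nH]c4ccccc4c3C[C@H]1[C@H](C#N)N1[C@@H](CNC(=O)/C=C/c3cccc(C(F)(F)F)c3)c3[nH]c4ccccc4c3C[C@@H]21` keeps the same core and changes the same position: 2-(3-(trifluoromethyl)phenyl)ethenyl in place of 1-benzofuran-2-yl on a carbonyl carbon. Among the compounds with values here, two measured steps touch this position. The step of a 1.9-fold lower number from compound 1 to compound 3 (0.27 log units; within the scatter) stays within the scatter, while a 3.1-fold lower number from compound 2 to compound 3 (0.49 log units; beyond the scatter) is modest. The step of a 1.6-fold higher number from compound 1 to compound 2 (0.21 log units; within the scatter) alters only a substituent on an aromatic ring and is within the scatter. Changes at the carbonyl carbon have so far shifted the number little, and nothing among the measured compounds resembles the entering group, so the expected step is small, with a lean toward a somewhat higher number than compound 3.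

For compound 4 in this assay the estimate is 450 nM, with a range from 150 nM to 1500 nM.

The step from compound 3 to compound 4 that this estimate implies is a 1.4-fold higher number from compound 3 to compound 4 (0.15 log units; within the scatter) and is expected to stay within the scatter.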

Compound 4, half-maximal inhibitory concentration: 110 nM
Compound 4: middle estimate off by 4.1-fold (0.61 log units), on the high side; measured number below the stated range.
By their numbers in this assay, from the lowest: compound 4; then compounds 3, 1 and 2 (each within the scatter of the next, the first and the last beyond it).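

In this assay, a 2.9-fold lower number from compound 3 to compound 4 (0.46 log units; beyond the scatter) and a 5.5-fold lower number from compound 1 to compound 4 (0.74 log units; beyond the scatter) and also an 8.9-fold lower number from compound 2 to compound 4 (0.95 log units; beyond the scatter) show that this position on the carbonyl carbon can move the number by more than the scatter from every earlier compound. Compound 4 now has the lowest number of the four, and its 2-(3-(trifluoromethyl)phenyl)ethenyl group is the only one here with a double bond outside aromatic rings. Nothing available explains why this change lowers the number.

Compound 4 differs from the others in both its ethenyl link and its trifluoromethyl group, so these compounds cannot show which part matters. A plain 2-phenylethenyl group would separate the two, while an amine or a carboxylic acid on the phenyl ring would test how far this position tolerates other groups.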